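A few compounds are considered here, and "the series" means these few. Any claim that something is new, unique, unknown or untested is made for them only; others in the source may bear on it.

Measured so far:
Compound 1, `O=c1[nH]cnc2c1c(-c1ccco1)cn2[C@@H]1O[C@H](CO)[C@@H](O)[C@H]1O`, gives > 100000 nM in an ADME assay on MRC5 cells (Homo sapiens), read by MTT assay, with a stated time of 72 h (a higher number here means a weaker inhibitor, a lower number a stronger inhibitor), which is a limit of that assay rather than a number.
Compound 2, `O=c1[nH]cnc2c1c(-c1cc3ccccc3o1)cn2[C@@H]1O[C@H](CO)[C@@H](O)[C@H]1O`, gives > 100000 nM in this assay, again a limit rather than a number.

For the measured compounds named here, compound 2 therefore stands at the upper limit of this assay, the place where every value so far sits (the limit of > 100000 nM in this assay, at which 2 of the 2 values shown sit). Going by the values given here, the only measured change, a step that the two limits leave unreadable from compound 1 to compound 2, has limits at both of its ends and cannot be sized, so it tells nothing about direction or size. Compound 3, `O=c1[nH]cnc2c1c(-c1ccccc1)cn2[C@@H]1O[C@H](CO)[C@@H](O)[C@H]1O`, differs from compound 2 by phenyl in place of 1-benzofuran-2-yl on an aromatic carbon. Among the compounds with values here, no measured step bears directly on this change; the sole guide is that compound 1 and compound 2 both sit at the limit in this assay. The expected step of a number no higher from compound 2 to compound 3 (the limit leaves the size open) is therefore none beyond the scatter, and the most likely outcome is that the assay again reports only a limit. Compound 3 is estimated at 100000 nM in this assay, with a range from 40000 nM to 300000 nM.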

Compound 3, half-maximal inhibitory concentration: > 100000 nM
Compound 3: a limit, no number; the forecaster's own chance of this, stated with the estimate: 85%; the middle value sits exactly at the limit.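

In this assay compound 3 gives > 100000 nM, again a limit and not a number. The steps linking compound 1, compound 2 and compound 3 therefore cannot be read, since all three sit at the same limit: the limit of > 100000 nM in this assay, at which 3 of the 3 values shown sit. Still open, going by these compounds, is whether the furan-2-yl, 1-benzofuran-2-yl and phenyl compounds differ at all in this assay.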